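The compounds below may be only part of what the source reports. "The series", "measured", "known", "first", "only" and "open" are said of these compounds alone.

In a functional assay on K562 cells (Homo sapiens) for antiproliferative activity, with a stated time of 72 h (a higher number here means a weaker inhibitor, a lower number a stronger inhibitor), the nucleoside compound 1 `OC[C@H]1O[C@@H](n2cnc3c(NCc4ccc(Cl)cc4Cl)ncnc32)[C@H](O)[C@@H]1O` gives 106000 nM, the higher of the two numbers recorded in this assay. Compound 3 `COc1ccc(CNc2ncnc3c2ncn3C2OC(CO)[C@@H](O)[C@H]2O)c(O)c1`, carrying a methoxy and a hydroxyl on its benzyl ring, gives 80800 nM, a value that sits within the scatter of compound 1, so the two cannot be ordered. Compound 2 `OC[C@H]1O[C@@H](n2cnc3c(NCc4cc(F)cc(F)c4)ncnc32)C(O)C1O` reaches only a limit of the assay, > 166000 nM, and no number. That limit of > 166000 nM in this assay, at which 1 of the 3 values shown sits, marks the edge of what this assay reports here.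

Compound 4 `OC[C@H]1O[C@@H](n2cnc3c(NCc4cccc(O)c4O)ncnc32)[C@H](O)[C@@H]1O` has not been measured in this assay. It differs from compound 1 in one place: 2,3-dihydroxyphenyl in place of 2,4-dichlorophenyl on a saturated chain carbon bound to a nitrogen on an aromatic ring. Among the measured compounds shown here, no measured step of this kind exists among the three compounds, so the expected size rests on the values alone. The step of a 1.1-fold higher number from compound 1 to compound 4 (0.05 log units; within the scatter) is expected to be small, in no firm direction, or none beyond the scatter. Compound 4 is therefore estimated at 120000 nM, within a range from 45000 nM to 320000 nM, with a real chance that only a limit is reported.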

Compound 4, half-maximal inhibitory concentration: 25800 nM
Compound 4: the middle estimate sits 4.7-fold (0.67 log units) above what was measured; measured number below the stated range.
By their numbers in this assay, from the lowest: compound 4; then compounds 3 and 1 (each within the scatter of the next). At a limit, above all of these: compound 2.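

The change from 2,4-dichlorophenyl to 2,3-dihydroxyphenyl gives a 4.1-fold lower number from compound 1 to compound 4 (0.61 log units; beyond the scatter) in this assay, the first single change shown whose size can be read at this position. It shows that the aryl group on this saturated chain carbon bound to a nitrogen on an aromatic ring can shift the antiproliferative read-out beyond the scatter, with the entering group carrying hydrogen-bond donors and acceptors and the leaving group none. Nothing measured here accounts for this shift.

The compounds shown leave open whether the lower number needs both hydroxyl groups or would persist with a single hydroxyl on the ring. They also leave open whether an amine or a carboxylic acid in place of these hydroxyl groups would lower the number further.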